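Furan-3-yl for Phenyl on an Inactive Core

This account rests on a few compounds, and the source may have more. Where it says the series, first, only, none or still open, it means among the compounds named here.

Compound 1 `COc1nc(N)nc2c1c(-c1ccccc1)cn2[C@@H]1O[C@H](CO)[C@@H](O)[C@H]1O` was tested in a functional assay on CEM-DNR-bulk cells (Homo sapiens), read by MTT assay, with a stated time of 72 h; a lower number here means a stronger inhibitor, a higher number a weaker inhibitor. In this assay compound 1 gives only a limit, > 20000 nM. For the measured compounds named here, its one measured neighbour, compound 2 `Nc1nc(N)c2c(-c3ccccc3)cn([C@@H]3O[C@H](CO)[C@@H](O)[C@H]3O)c2n1`, carries amino in place of methoxy on an aromatic carbon. In this assay compound 2 likewise gives only a limit, > 20000 nM. The step that the two limits leave unreadable from compound 1 to compound 2 therefore cannot be read, since (the limit of > 20000 nM in this assay, at which 2 of the 2 values shown sit). Going by the values given here, compound 1 thus stands at the limit alongside the only other compound measured, with no number to place it.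

The unmeasured compound 3 `COc1nc(N)nc2c1c(-c1ccoc1)cn2[C@@H]1O[C@H](CO)[C@@H](O)[C@H]1O` differs from compound 1 in one place: furan-3-yl in place of phenyl on an aromatic carbon. Among the compounds with values here, no measured step touches this position, and the one measured step is unreadable, so nothing here speaks for a change in either direction. The shared core of compound 1 has so far yielded no measurable value. Compound 3 is therefore expected to remain at the limit as well, with the step that the limit leaves unreadable from compound 1 to compound 3 expected to be none beyond the scatter. The estimate for compound 3 is 40000 nM, between 10000 nM and 200000 nM.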

Compound 3, half-maximal inhibitory concentration: > 20000 nM
Compound 3: a limit, no number; the forecaster's own chance of this, stated with the estimate: 80%; the middle value does not contradict the limit.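

In this assay compound 3 gives > 20000 nM, which is a limit and not a number. The step from compound 1 to compound 3, furan-3-yl in place of phenyl, therefore cannot be read: the limit of > 20000 nM in this assay, at which 3 of the 3 values shown sit. The compounds shown leave open whether any compound on the shared core reaches a measurable value in this assay.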